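The source may report more compounds than this note shows. Statements on the series, on what has been measured and on what is new or still open speak of the compounds shown alone.

Compound 1 `Nc1cc(N)c2nc(-c3ccccc3)c(Sc3ccc(F)cc3)nc2c1`: 45700 nM
Compound 2 `COc1cc(CNc2nc3cc(N)cc(N)c3nc2-c2ccccc2)cc(OC)c1OC`: 19500 nM

Both compounds were tested in a functional assay on HT-29 cells (Homo sapiens) for inhibition, read by sulforhodamine B assay, with a stated time of 48 h; a lower number here means a stronger inhibitor of growth, a higher number a weaker inhibitor of growth. Of the two numbers, compound 2 gives the lower one, while compound 1 gives a higher number, a gap beyond the usual scatter. Compound 3 `COc1ccc(CNc2nc3cc(N)cc(N)c3nc2-c2ccccc2)cc1OC` has not yet been measured. It differs from compound 2 in one place: hydrogen in place of methoxy on an aromatic carbon. Going by the values given here, no step between measured compounds is known, so nothing here shows how much one methoxy group matters. The step of a 1.3-fold higher number from compound 2 to compound 3 (0.11 log units; within the scatter) is expected to be small, within the scatter, leaning if anything toward a higher number. Compound 3 is therefore estimated at 25000 nM, in a range from 10000 nM to 60000 nM.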

Compound 3, concentration for total growth inhibition: 24500 nM
Compound 3: middle estimate off by 1.0-fold (0.01 log units), on the high side, and the stated range covers the measured number.
By their numbers in this assay, from the lowest: compounds 2, 3 and 1 (each within the scatter of the next, the first and the last beyond it).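

Replacing methoxy with hydrogen on this aromatic carbon gives a 1.3-fold higher number from compound 2 to compound 3 (0.10 log units; within the scatter) in this assay, so the two numbers cannot be told apart. This first step between measured compounds shows that this one methoxy group, ortho to a methoxy group and meta to a large group, is not needed to keep the number of compound 2 within the scatter. No available data bear on the reason for this result.

As far as these compounds go, whether an amine or a longer ethoxy chain at this carbon would also stay within the scatter remains open. So does the effect of removing the other methoxy groups.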